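Compound 2 to compound 3: a pyridyl amide after two limits

The compounds below may be only part of what the source reports. "The series", "measured", "known", "first", "only" and "open" are said of these compounds alone.

Measured compounds:
Compound 1 `Cc1cc(Cl)ccc1C(=O)Nc1ccc(Cl)c(-c2nnc3c(Cl)cccn23)c1`: > 100000 nM
Compound 2 `O=C(Nc1ccc(Cl)c(-c2nnc3c(Cl)cccn23)c1)c1c(F)cccc1Cl`: > 100000 nM

Both values come from a functional assay on MDA-MB-231 cells (Homo sapiens) for antiproliferative activity, read by MTT assay, with stated times of 72 h and 4 h; a lower number here means a stronger inhibitor, a higher number a weaker inhibitor. In this assay compound 1 reaches only a limit of the assay, > 100000 nM. Compound 2 likewise stops at a limit, > 100000 nM. The step that the two limits leave unreadable from compound 1 to compound 2 can therefore not be read in size or direction. The whole of the evidence is the limit of > 100000 nM in this assay, at which 2 of the 2 values shown sit, so compound 2 stands at the upper edge of what this assay reports, without a number of its own.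

Compound 3 `O=C(Nc1ccc(Cl)c(-c2nnc3c(Cl)cccn23)c1)c1cccnc1Cl` has not yet been measured. It differs from compound 2 by 2-chloropyridin-3-yl in place of 2-chloro-6-fluorophenyl on a carbonyl carbon. Among the measured compounds shown here, no measured step bears on this change with a readable size; the one step that exists is unreadable, and compound 2 sits at the limit. The expectation for compound 3 in this assay is therefore that it stays at the limit as well, with an estimated step that the limit leaves unreadable from compound 2 to compound 3, meaning no change beyond the scatter. Compound 3 is estimated at 150000 nM in this assay, within a range from 30000 nM to 600000 nM.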

Compound 3, half-maximal inhibitory concentration: 89700 nM
Compound 3: the middle estimate sits 1.7-fold (0.22 log units) above what was measured; the range from low to high includes it.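

With 2-chloropyridin-3-yl on the carbonyl carbon, this position yields a number rather than a limit for the first time among the compounds shown: in this assay, compound 3 gives 89700 nM. Going by these compounds, the change from 2-chloro-6-fluorophenyl is an at least 1.1-fold lower number from compound 2 to compound 3 (0.04 log units; that floor lies within the scatter), and the change from 4-chloro-2-methylphenyl is an at least 1.1-fold lower number from compound 1 to compound 3 (0.04 log units; that floor lies within the scatter); both are floors only, so neither change can be told from the scatter, and their true size remains unknown. Compound 3 therefore gives the series a reading of its own, but the other two compounds offer no number to set against it: the limit of > 100000 nM in this assay, at which 2 of the 3 values shown sit.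

The compounds shown leave open how large the step to 2-chloropyridin-3-yl really is, and whether any group on this carbonyl carbon can move the number clearly beyond the scatter. They also leave open what an amine, a carboxylic acid or a longer alkyl chain would give in that place, on the same core, in this assay.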